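This account rests on a few compounds, and the source may have more. Where it says the series, first, only, none or still open, it means among the compounds named here.

Measured so far:
- compound 1 `O=C(Nc1ccccc1)c1cccc(Br)c1O` — > 100000 nM, a limit of the assay
- compound 2 `O=C(Nc1ccc(Sc2nc3ccccc3s2)c(Cl)c1)c1cccc(Br)c1O` — 6900 nM
- compound 3 `O=C(Nc1cccc(Cl)c1)c1cccc(Br)c1O` — > 100000 nM, a limit of the assay

In an assay for inhibition of HSP60/HSP10 (Homo sapiens), with a stated time of 60 min (on this read-out lower numbers stand for stronger inhibition and higher numbers for weaker inhibition), compound 1 gives only a limit, > 100000 nM. Compound 3 likewise gives only a limit, > 100000 nM. Going by the values given here, compound 2 is the sole member of the series with a numerical value in this assay, 6900 nM. Compound 1 therefore stands at the weak end of what has been measured, with no number of its own.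

Among the compounds with values here, the one measured step that starts from compound 1, a step that the two limits leave unreadable from compound 1 to compound 3, cannot be sized because the limit of > 100000 nM in this assay, at which 2 of the 3 values shown sit, holds both of its ends.

Compound 4 `O=C(Nc1ccccc1)c1cccc(Br)c1` differs from compound 1 in one place: hydrogen in place of hydroxy on an aromatic carbon. Within the data shown here, no measured step removes a hydroxy, and the only step recorded concerns a chloro, so nothing measured bears directly on this change. Compound 1 sits at the limit, and compound 4 is expected to remain there as well, most likely again reported only as a limit. The expected step that the limit leaves unreadable from compound 1 to compound 4 is an estimate, not a measurement. For compound 4 the estimate is 150000 nM, with a range from 50000 nM to 500000 nM.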

Compound 4, half-maximal inhibitory concentration: > 100000 nM
Compound 4 ended at the assay's limit; the forecaster's own chance of this, stated with the estimate: 85%; the middle value is on the limit's open side.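

No new step can be read between compound 1 and compound 4 in this assay, because both values are limits of the assay rather than numbers: the limit of > 100000 nM in this assay, at which 3 of the 4 values shown sit.

The compounds shown leave open whether hydrogen in place of hydroxy on an aromatic carbon changes the read-out where a numerical value exists, as for compound 2 at 6900 nM.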